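Amino substitution on the anilino ring of compound 1

The source may hold more compounds than are shown below. What is called first, only, known or untested is meant among the compounds shown, and "the series" means these compounds.

Compound 1 `Fc1cccc(-c2nc(Nc3ccccc3)c3cc(F)ccc3n2)c1` holds the only numerical read-out in this pair: in a functional assay on MDA-MB-231 cells (Homo sapiens) for cytotoxicity, read by MTT assay, with a stated time of 48 h (a higher number here means a weaker inhibitor, a lower number a stronger inhibitor), compound 1 gives 47800 nM. Compound 2 `Fc1cccc(-c2nc(Nc3ccc(Br)cc3)c3cc(F)ccc3n2)c1` carries bromo in place of hydrogen on an aromatic carbon of the anilino group. In this assay compound 2 gives > 50000 nM, which is a limit of the assay and not a number. The step of an at least 1.0-fold higher number from compound 1 to compound 2 (0.01 log units; that floor lies within the scatter) runs into the limit of > 50000 nM in this assay, at which 1 of the 2 values shown sits, and so fixes only a floor that itself sits within the scatter.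

Compound 3 `Nc1cccc(Nc2nc(-c3cccc(F)c3)nc3ccc(F)cc23)c1` differs from compound 1 by amino in place of hydrogen on an aromatic carbon. Among the measured compounds shown here, the single measured step concerns a different group and a different place on the anilino ring, so it bears on this change only indirectly; it shows that substitution of that ring did not move the number beyond the scatter. For compound 3 the expectation in this assay is accordingly a step of a 1.2-fold lower number from compound 1 to compound 3 (0.08 log units; within the scatter), not beyond the scatter. The estimate for compound 3 is 40000 nM, expected to fall between 15000 nM and 100000 nM.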

Compound 3, half-maximal inhibitory concentration: > 50000 nM
Compound 3: no number, only a limit (the forecaster's own chance of this, stated with the estimate: 30%); middle value at least 1.2-fold (0.09 log units) from the limit.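

Compound 3 gives > 50000 nM, which is a limit of the assay and not a number. In this assay, among the compounds shown here, the amino change gives an at least 1.0-fold higher number from compound 1 to compound 3 (0.01 log units; that floor lies within the scatter), so a second substituent on the anilino ring, different in kind and printed as meta to a large group, again fixes only a floor and shows no step to a lower number. Neither substituted compound yields a measured number, and the step between compound 2 and compound 3 cannot be read, which leaves the effect of these substituents unresolved in this series: the limit of > 50000 nM in this assay, at which 2 of the 3 values shown sit.

From the compounds shown here alone, how far compound 2 and compound 3 actually lie past the limit stays open. Also open, going by these compounds, is whether a methoxy group or a carboxylic acid at this place on the anilino ring would give a number that can be read.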